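Halogen swap on the shared core: cytotoxicity notes

The compounds below may be only part of what the source reports. "The series", "measured", "known", "first", "only" and "open" are said of these compounds alone.

Compound 1 `Cc1ccc2nc(NCCCCOc3cc(O)c4c(=O)cc(-c5ccccc5)oc4c3)sc2c1` gives 294 ug/mL in an ADME assay on MDCK cells (Canis lupus familiaris) for cytotoxicity, read by sulforhodamine B assay, with a stated time of 48 h; a lower number here means a stronger inhibitor, a higher number a weaker inhibitor. Compound 2 `O=c1cc(-c2ccccc2)oc2cc(OCCCCNc3nc4ccc([N+](=O)[O-])cc4s3)cc(O)c12` gives 310 ug/mL in this assay, and compound 3 `O=c1cc(-c2ccccc2)oc2cc(OCCCCNc3nc4ccc(Cl)cc4s3)cc(O)c12` gives 338 ug/mL in this assay. All three numbers sit together: a 1.1-fold higher number from compound 1 to compound 2 (0.02 log units; within the scatter), a 1.1-fold higher number from compound 1 to compound 3 (0.06 log units; within the scatter), a 1.1-fold higher number from compound 2 to compound 3 (0.04 log units; within the scatter). Compound 3 is thus indistinguishable from the other two on these numbers.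

Compound 4 `O=c1cc(-c2ccccc2)oc2cc(OCCCCNc3nc4ccc(F)cc4s3)cc(O)c12` differs from compound 3 by fluoro in place of chloro on an aromatic carbon. Within the data shown here, the steps that bear on this position, methyl to nitro, methyl to chloro and nitro to chloro, all stayed within the scatter, so no step beyond the scatter is expected in this assay from this change: a 1.1-fold lower number from compound 3 to compound 4 (0.02 log units; within the scatter). Compound 4 is therefore estimated at 320 ug/mL, expected between 200 ug/mL and 500 ug/mL.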

Compound 4, half-maximal inhibitory concentration: 324 ug/mL
Beside the measured number, compound 4's estimate is 1.0-fold (0.01 log units) below it; the range from low to high includes it.
By their numbers in this assay, from the lowest: compounds 1, 2, 4 and 3 (each within the scatter of the next).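

In this assay, fluoro extends the flat reading at this position to a second halogen, with a 1.0-fold lower number from compound 3 to compound 4 (0.02 log units; within the scatter) and a 1.0-fold higher number from compound 2 to compound 4 (0.02 log units; within the scatter) and a 1.1-fold higher number from compound 1 to compound 4 (0.04 log units; within the scatter). Methyl, nitro, chloro and fluoro on this aromatic carbon now all read alike, so none of these four groups separates from the others. The data offer no explanation for this flat reading.

Still open, from the compounds shown here alone, is whether an amine or a carboxylic acid on this aromatic carbon would leave the reading unchanged. A longer chain on the shared core also remains an open question.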